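Methoxy on the oxindole-type ring of compound 3

The source may report more compounds than this note shows. Statements on the series, on what has been measured and on what is new or still open speak of the compounds shown alone.

Three compounds have numbers in a functional assay on cells (Cancer cell lines, Homo sapiens) for cytotoxicity, with a stated time of 48 h; a lower number here means a stronger inhibitor of growth, a higher number a weaker inhibitor of growth. Compound 1 `COc1cc2c(/C=C3/C(=O)Nc4ccc(Cl)cc43)c(Cl)n(Cc3cc(OC)c(OC)c(OC)c3)c2cc1C` gives 6030 nM, compound 2 `COc1cc2c(/C=C3/C(=O)Nc4cccc(Cl)c43)c(Cl)n(Cc3cc(OC)c(OC)c(OC)c3)c2cc1C` gives 12600 nM, and compound 3 `COc1c(/C=C2/C(=O)Nc3ccccc32)c2ccccc2n1-c1ccccc1` gives 8510 nM. Compound 3 stands second highest of the three; its gaps to compound 1 and to compound 2 are both within the scatter. Within the data shown here, the only measured step, a 2.1-fold higher number from compound 1 to compound 2 (0.32 log units; beyond the scatter), exchanges one group for another of matching size and does not touch a methoxy. Compound 4 `COc1ccc2c(c1)/C(=C\c1c(OC)n(-c3ccccc3)c3ccccc13)C(=O)N2` carries methoxy in place of hydrogen on an aromatic carbon, the place being part of a fused system of two rings, meta to a fused ring and para to a fused ring. Among the measured compounds shown here, no measured step bears on this change, so the expected step of a 1.1-fold lower number from compound 3 to compound 4 (0.03 log units; within the scatter) is none beyond the scatter. Compound 4 is therefore estimated at 8000 nM, within 3000 nM to 20000 nM.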

Compound 4, concentration for total growth inhibition: 9550 nM
Compound 4: middle estimate off by 1.2-fold (0.08 log units), on the low side, and the stated range covers the measured number.
By their numbers in this assay, from the lowest: compounds 1, 3, 4 and 2 (each within the scatter of the next, the first and the last beyond it).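

In this assay, methoxy in place of hydrogen on an aromatic carbon, meta to a fused ring and para to a fused ring, gives a 1.1-fold higher number from compound 3 to compound 4 (0.05 log units; within the scatter) and so shows no change beyond the scatter. Among these compounds, this is the first reading of this position, and here it tolerates methoxy without a measurable loss or gain. No available measurement accounts for this result.

From the compounds shown here alone, whether an amine or a carboxylic acid at this place would read the same remains open. So does whether methoxy here would behave alike on the core of compound 1.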